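Notes on a sulfonyl-substituted xanthine series

A few compounds are considered here, and "the series" means these few. Any claim that something is new, unique, unknown or untested is made for them only; others in the source may bear on it.

Measured so far:
compound 1 `Cn1c(-c2ccc(S(=O)(=O)O)cc2)nc2c1c(=O)[nH]c(=O)n2C`: 1.8%
compound 2 `Cn1c(-c2ccc(S(N)(=O)=O)cc2)nc2c1c(=O)[nH]c(=O)n2C`: 33%

In an assay on membranes from brain for binding affinity to adenosine receptor A1 (Rattus norvegicus), tested at 100 uM (a higher number here means more inhibition at the concentration tested (going by the name of the read-out), a lower number less inhibition), compound 1 gives 1.8% and compound 2 gives 33%. Within the data shown here, compound 1 stands at the lower of the two numbers; its nearest neighbour is compound 2, reached by a number 31.2 percentage points higher from compound 1 to compound 2 (beyond the scatter), the only change with a known outcome in this set.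

Compound 3 `Cn1c(=O)c2c(nc(-c3ccc(S(=O)(=O)O)cc3)n2C)n(C)c1=O` differs from compound 1 in a single place: methyl in place of hydrogen on an aromatic nitrogen. Among the measured compounds shown here, no measured step concerns this change. The step from compound 1 to compound 2 alters the substituent on the sulfonyl sulfur and leaves the core untouched, so it does not bear on a methyl entering on an aromatic nitrogen of the core. What the numbers do show is that compound 1 sits near the bottom of the readout, which leaves little room for a downward step in this assay and no evidence for an upward one. The expected change is therefore a number 1.2 percentage points higher from compound 1 to compound 3 (within the scatter), not beyond the scatter. Compound 3 is estimated at 3%, between 0% and 15%.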

Compound 3, a percentage reported as inhibition, at one concentration (the size of the read-out at that concentration, not a potency): 3.3%
Beside the measured number, compound 3's estimate is 0.3 percentage points below it; the range from low to high includes it.
By their numbers in this assay, from the lowest: compounds 1 and 3 (each within the scatter of the next); then compound 2.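

Working note on the aromatic nitrogen: this position now has its first direct reading, taken with the hydroxy on the sulfonyl sulfur held constant. In this assay, methyl in place of hydrogen gives a number 1.5 percentage points higher from compound 1 to compound 3 (within the scatter), so at this one position and with this one substituent on the sulfur, the exchange has no effect that can be told from the usual scatter of the read-out. Nothing at hand offers an explanation for this result.

The reading is tied to the hydroxy-bearing sulfonyl compounds, so the compounds shown leave open whether the same methyl would behave alike with the amino group on the sulfonyl sulfur, the setting of compound 2 at 33%. They also leave open whether a longer chain on this nitrogen, such as propyl, or a benzyl group would depart from hydrogen and methyl, and whether a carboxylic acid in place of the sulfonyl group on the phenyl ring would change the picture at this position.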